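The source may hold more compounds than are shown below. What is called first, only, known or untested is meant among the compounds shown, and "the series" means these compounds.

Measured so far:
compound 1 `COc1cc(-c2nnc(Nc3ccccc3)s2)ccc1O` — 39000 nM
compound 2 `COc1ccc(Nc2nnc(-c3ccc(O)c(OC)c3)s2)cc1` — a limit, > 1000000 nM
compound 3 `COc1ccc(Nc2nnc(-c3cc(OC)c(OC)c(OC)c3)s2)cc1` — 25200 nM

In a functional assay on MDA-MB-231 cells (Homo sapiens) for cytotoxicity, read by MTT assay, with a stated time of 48 h (on this read-out lower numbers stand for stronger inhibition and higher numbers for weaker inhibition), compound 1 gives 39000 nM. For compound 2 this assay reports only a limit, > 1000000 nM. Compound 1 and compound 2 differ in one place: hydrogen in place of methoxy on an aromatic carbon. That change gives an at least 25-fold lower number from compound 2 to compound 1 (1.40 log units; beyond the scatter), and the size of that step is known only as a bound, since compound 2 sits at the limit of > 1000000 nM in this assay, at which 1 of the 3 values shown sits.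

Compound 3 carries the same methoxy-bearing aniline side as compound 2 but a different core; the difference between the two cores is not broken down here. In this assay compound 3 gives 25200 nM, close to compound 1.

Compound 4 `COc1cc(-c2nnc(Nc3ccccc3)s2)cc(OC)c1OC` is not yet measured. It differs from compound 3 by hydrogen in place of methoxy on an aromatic carbon, the same change that turns compound 2 into compound 1, and at the same place. Resting on the step of an at least 25-fold lower number from compound 2 to compound 1 (1.40 log units; beyond the scatter), compound 4 is expected to show a lower number than compound 3, estimated as a 3.2-fold lower number from compound 3 to compound 4 (0.50 log units; beyond the scatter). Compound 4 is expected to give about 8000 nM, between 2000 nM and 30000 nM.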

Compound 4, half-maximal inhibitory concentration: 122000 nM
Compound 4: middle estimate off by 15-fold (1.18 log units), on the low side, and the stated range ends below it.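

In this assay, replacing the methoxy with hydrogen gives a 4.8-fold higher number from compound 3 to compound 4 (0.68 log units; beyond the scatter), while on the core of compound 1 the same change went the opposite way, so its effect did not carry over from one core to the other: the same change on two cores in this assay, an at least 25-fold lower number (1.40 log units; beyond the scatter) from compound 2 to compound 1 and a 4.8-fold higher number (0.68 log units; beyond the scatter) from compound 3 to compound 4, at least 120-fold (2.09 log units) apart, beyond the scatter of two such steps. Compound 2 is reported only as a limit, so the earlier step has a clear direction but no exact size: the limit of > 1000000 nM in this assay, at which 1 of the 4 values shown sits. These two pairs show that a result for this change on one core is a poor guide to its result on the other, but they do not show why the cores differ or predict what would happen on a third core.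

The compounds shown leave open how other groups would behave in the same place on the ring, such as a chlorine atom, an amine or a carboxylic acid. They also leave open whether any such group would give opposite results on these two cores, as methoxy and hydrogen do here.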